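The source may hold more compounds than are shown below. What is called first, only, known or untested is meant among the compounds shown, and "the series" means these compounds.

In a functional assay on HCT-116 cells (Homo sapiens) for antiproliferative activity, read by sulforhodamine B assay, with a stated time of 72 h (on this read-out higher numbers stand for weaker inhibition and lower numbers for stronger inhibition), the three measured compounds leave little to read. Compound 2 `Cn1cc(-c2ccc(=O)n(CCOc3ccnc4cc(OCCCCCC(=O)NO)ccc34)n2)cn1` gives > 10000 nM, which is a limit and not a number. Compound 1 `Cn1cc(-c2ccc(=O)n(CCOc3ccnc4cc(OCCCCC(=O)NO)ccc34)n2)cn1` gives > 10000 nM, also a limit. This is the limit of > 10000 nM in this assay, at which 2 of the 3 values shown sit. Among the compounds with values here, compound 3 `Cn1cc(-c2ccc(=O)n(CCOc3ccnc4cc(OCCCCCC(=O)Nc5ccccc5N)ccc34)n2)cn1` gives 7000 nM, the only actual number in the set.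

Lengthening the chain is a step that the two limits leave unreadable from compound 1 to compound 2. Placing 2-aminophenyl on the amide-type nitrogen is an at least 1.4-fold lower number from compound 2 to compound 3 (0.15 log units; that floor lies within the scatter), and the matching comparison is an at least 1.4-fold lower number from compound 1 to compound 3 (0.15 log units; that floor lies within the scatter).

Compound 4 `CC(=O)CCCCCOc1ccc2c(OCCn3nc(-c4cnn(C)c4)ccc3=O)ccnc2c1` carries methyl in place of hydroxyamino on a carbonyl carbon, so hydroxycarbamoyl becomes acetyl: methyl in place of hydroxyamino on a carbonyl carbon. Within the data shown here, no measured step makes this change. The closest is the change at the same carbonyl in compound 3, and an at least 1.4-fold lower number from compound 2 to compound 3 (0.15 log units; that floor lies within the scatter) has a floor within the scatter. No step beyond the scatter is therefore expected in this assay, and a reading that reports only the limit is likely.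

The expected move is a step that the limit leaves unreadable from compound 2 to compound 4. The estimated value for compound 4 is 15000 nM, with an expected range of 7000 nM to 30000 nM.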

Compound 4, half-maximal inhibitory concentration: > 10000 nM
Compound 4: a limit, no number; the forecaster's own chance of this, stated with the estimate: 85%; the middle value is on the limit's open side.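

With acetyl in place of hydroxycarbamoyl, compound 4 gives a limit and no number in this assay, so methyl in place of hydroxyamino on this carbonyl carbon does not bring the series off that limit: the limit of > 10000 nM in this assay, at which 3 of the 4 values shown sit. The steps to compound 4 from compound 1 and from compound 2 cannot be read, with limits at both ends. The only readable new step is an at least 1.4-fold higher number from compound 3 to compound 4 (0.15 log units; that floor lies within the scatter), so compound 3 and compound 4 are not shown to differ beyond the scatter.

From the compounds shown here alone, what hydroxyamino itself contributes at this carbonyl carbon stays open, with compound 1, compound 2 and compound 4 all reported only as limits. Also open, going by these compounds, are how a carboxylic acid at this carbonyl carbon would read and whether a longer chain would change the reading of compound 3.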